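Methoxy for Methoxycarbonyl: What the Next Compound May Show

The compounds below may be only part of what the source reports. "The series", "measured", "known", "first", "only" and "open" are said of these compounds alone.

Measured so far:
compound 1 `CNCCN(C)c1nnnn1Cc1cccc(C(F)(F)F)c1`: 8%
compound 2 `CNCCN(C)Cc1ccc(-c2ccc(C(=O)OC)cc2)o1`: 32%

Of the compounds shown here, two have been measured in an assay on cells for inhibition of protein arginine N-methyltransferase 1 (Homo sapiens), read by scintillation counting, with stated times of 15 min and 60 min, tested at 9 uM; on this read-out lower numbers stand for less inhibition and higher numbers for more inhibition at the one concentration tested (going by the name of the read-out). Compound 1 `CNCCN(C)c1nnnn1Cc1cccc(C(F)(F)F)c1` gives 8%, while compound 2 `CNCCN(C)Cc1ccc(-c2ccc(C(=O)OC)cc2)o1` gives 32%. Among the measured compounds shown here, compound 2 therefore stands highest of the two numbers; its only neighbour, compound 1, sits well below it, a gap beyond the usual scatter of repeated measurements. For the measured compounds named here, the two compounds differ in many places at once, so no step between compounds that differ in a single place is available, and nothing measured yet tells how a single change moves the read-out.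

Compound 3 `CNCCN(C)Cc1ccc(-c2ccc(OC)cc2)o1` has not been measured. It differs from compound 2 in one place: methoxy in place of methoxycarbonyl on an aromatic carbon. The anchor is compound 2 with its 32%. Going by the values given here, with no single-place step to go by, the change is expected to be modest, either a small decrease or none beyond the scatter, and the expected step is a number 10 percentage points lower from compound 2 to compound 3 (within the scatter). Compound 3 is expected to give about 22%, within 5% to 40%.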

Compound 3, a percentage reported as inhibition, at one concentration (the size of the read-out at that concentration, not a potency): 38%
Beside the measured number, compound 3's estimate is 16 percentage points below it; low and high end bracket the measured number.
By their numbers in this assay, from the lowest: compound 1; then compounds 2 and 3 (each within the scatter of the next).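

In this assay, among the compounds shown here, the first step at a single place is a number 6 percentage points higher from compound 2 to compound 3 (within the scatter), with methoxy in place of methoxycarbonyl on an aromatic carbon, para to a large group. At this position, then, the read-out does not separate the two groups, although the methoxycarbonyl that leaves has 4 heavy atoms and a double bond outside aromatic rings, while the methoxy that enters has 2 heavy atoms and no such bond; in this pair, inhibition at the one concentration tested does not depend on keeping the carbonyl. Nothing available bears on why the two groups read alike, so this outcome stands without an explanation.

The compounds shown leave open whether a hydroxyl group, an amine or a carboxylic acid on the same aromatic carbon would read like these two groups or move the number beyond the scatter. For the compounds shown here, they also leave open how a change elsewhere, such as a longer chain at the amine end shared by compound 2 and compound 3, would act, and a single tested concentration gives no potency for either compound.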